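The compounds below may be only part of what the source reports. "The series", "measured", "known", "first", "only" and "open" are said of these compounds alone.

Values measured in a functional assay on U-373MG ATCC cells for cytotoxicity against U373 MG (Homo sapiens), read by colorimetric assay and MTT assay; on this read-out lower numbers stand for stronger inhibition and higher numbers for weaker inhibition:

- Compound 1 `COc1ccc2cc(-c3ccccc3)c(O)nc2c1`: 10000 nM
- Compound 2 `COc1ccc(-c2cc3c(OC)ccc(OC)c3nc2O)cc1`: 10000 nM
- Compound 3 `CCN(CC)C(=O)Cn1c(=O)c(-c2ccc(OC)cc2)cc2c(OC)cc(OC)cc21`: 10000 nM

The three compounds cannot be told apart on these numbers. Compound 3 stands level with compound 1 and compound 2, and the gaps to both lie within the scatter. Compound 4 `COc1ccc(-c2cc3c(OC)cc(OC)cc3n(CCC(=O)OCc3ccccc3)c2=O)cc1` has not yet been measured. It carries (benzyloxycarbonyl)methyl in place of diethylcarbamoyl on a saturated chain carbon bound to an aromatic nitrogen.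

Within the data shown here, no pair of measured compounds differs in one place only, so the data give no direct measure of what such a change does. Among the measured compounds shown here, the only guide is compound 3 at 10000 nM, together with the matching values of the other two compounds. On that basis, no step beyond the scatter is expected in this assay, in either direction. The expected change is no change at the digits printed from compound 3 to compound 4 (within the scatter), and it remains an estimate. Compound 4 is expected at 10000 nM, with an estimated range of 4000 nM to 20000 nM.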

Compound 4, half-maximal inhibitory concentration: 10000 nM
Compound 4: the middle estimate sits on the measured number at the digits printed; the measured number falls inside the stated range.
By their numbers in this assay, from the lowest: compounds 1, 2, 3 and 4 (each within the scatter of the next).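

In this assay, among these compounds, the first step between two compounds that differ in one place reads no change at the digits printed from compound 3 to compound 4 (within the scatter), which gives this position a direct comparison that the earlier compounds lacked. On a saturated chain carbon bound to an aromatic nitrogen, (benzyloxycarbonyl)methyl in place of diethylcarbamoyl thus brings in a six-membered aromatic ring of carbon only, and the printed number stays the same. No measurement is available that would explain this result.

As far as these compounds go, whether a carboxylic acid or a tertiary amine on this chain would shift the number remains open. All four compounds print the same value in this assay, so the compounds shown identify no group at this position that moves the read-out.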